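The source may hold more compounds than are shown below. What is called first, only, known or untested is meant among the compounds shown, and "the series" means these compounds.

Measured in a functional assay on J774 cells (Mus musculus) for cytotoxicity, read by resazurin assay, with a stated time of 72 h; a higher number here means a weaker inhibitor, a lower number a stronger inhibitor:
- compound 1 `O=S(=O)(Nc1cccc(CO)c1)c1ccc(-c2ccccc2)cc1`: 2200 nM
- compound 2 `O=S(=O)(Nc1cccc(CO)c1O)c1ccc(-c2ccc(Br)cc2)cc1`: > 5000 nM (a limit of the assay)
- compound 3 `O=S(=O)(Nc1cccc(CO)c1)c1ccc(-c2ccc3[nH]ccc3c2)cc1`: > 5000 nM (a limit of the assay)

Compound 3 has no number, only a limit, > 5000 nM. This is the limit of > 5000 nM in this assay, at which 2 of the 3 values shown sit. Compound 4 `O=S(=O)(Nc1cccc(CO)c1)c1ccc(-c2ccc3cc[nH]c3c2)cc1` has the same atoms as compound 3, joined differently: 1H-indol-6-yl in place of 1H-indol-5-yl on an aromatic carbon. The 1H-indol-6-yl group takes the place of 1H-indol-5-yl on an aromatic carbon, para to a large group.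

Going by the values given here, one measured step bears on this change: an at least 2.2-fold higher number from compound 1 to compound 3 (0.35 log units; beyond the scatter), at least modest and beyond the scatter, with 1H-indol-5-yl in place of phenyl. Among the compounds with values here, no measured step moves the point of attachment of such a group, so the data give no direction for this change. In this assay, no step beyond the scatter is therefore expected, and compound 4 may well also reach the limit. The expected step is a number no higher from compound 3 to compound 4 (the limit leaves the size open). For compound 4 the estimated value is 5000 nM, with an expected range from 2200 nM to 11000 nM.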

Compound 4, half-maximal inhibitory concentration: 2500 nM
The estimate for compound 4 lay 2.0-fold (0.30 log units) above the measured number, and the stated range covers the measured number.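

In this assay the change from 1H-indol-5-yl to 1H-indol-6-yl gives an at least 2.0-fold lower number from compound 3 to compound 4 (0.30 log units; that floor lies within the scatter), so this step shows no change beyond the scatter, though what it prints is only a floor. Compound 3 holds a limit of the assay, not a number: the limit of > 5000 nM in this assay, at which 2 of the 4 values shown sit. Going by these compounds alone, the swap of phenyl for 1H-indol-6-yl gives a 1.1-fold higher number from compound 1 to compound 4 (0.06 log units; within the scatter), which shows that an indole group in this place, para to a large group, does not by itself reach the limit, a possibility the earlier compounds had left standing.

The compounds shown leave open how large the step between the two indoles really is. They also leave open whether a 1H-indol-4-yl group, a carboxylic acid or an amine in the same place would stay level with these values or reach the limit.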